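The source may hold more compounds than are shown below. What is called first, only, known or untested is meant among the compounds shown, and "the series" means these compounds.

In a functional assay (muscle tissue) with Cavia porcellus as the target (a lower number here means that less compound is needed, a higher number that more compound is needed for the effect), two compounds have been measured so far. Compound 1 `COC(=O)C1=C(C)N=C(C)/C(=C(\O)OC)C1c1ccccc1OC` gives 57.5 nM in this assay, while compound 2 `C=Cc1ccccc1C1C(C(=O)OC)=C(C)N=C(C)/C1=C(\O)OC` gives 4.47 nM as the lower of the two numbers. For the measured compounds named here, the one measured step, a 13-fold lower number from compound 1 to compound 2 (1.11 log units; beyond the scatter) with vinyl in place of methoxy on an aromatic carbon, lies beyond the scatter.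

The next structure, compound 3 `COC(=O)C1=C(C)N=C(C)/C(=C(\O)OC)C1c1cccc(C#N)c1`, has not yet been measured. In it, 3-cyanophenyl stands in place of 2-vinylphenyl on a saturated ring carbon 3-cyanophenyl in place of 2-vinylphenyl on a saturated ring carbon and the rest of the structure stays the same. Going by the values given here, the step to compound 2 is the only evidence that bears on this change, and it bears loosely. Among the compounds with values here, it shows that swapping a group on this aromatic ring can move the number widely, but no measured compound carries a nitrile or has its group placed as in compound 3.

A step beyond the scatter is therefore not expected, though the range must stay wide. The estimate for compound 3 is 7 nM in this assay with an expected range from 2 nM to 30 nM for its measurement. This estimate means a 1.6-fold higher number from compound 2 to compound 3 (0.19 log units; within the scatter) as the expected step.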

Compound 3, half-maximal effective concentration: 34.7 nM
For compound 3 the middle estimate is 5.0-fold (0.70 log units) below the measured one; measured number outside the range, above it.
By their numbers in this assay, from the lowest: compound 2; then compounds 3 and 1 (each within the scatter of the next).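

At this position on the saturated ring carbon, the replacement of 2-vinylphenyl by 3-cyanophenyl gives a 7.8-fold higher number from compound 2 to compound 3 (0.89 log units; beyond the scatter) in this assay and so moves the number beyond the scatter, which shows that the low number of compound 2 does not carry over to this other substituted phenyl group. Compound 3 instead stands with compound 1, with a 1.7-fold lower number from compound 1 to compound 3 (0.22 log units; within the scatter) from 2-methoxyphenyl to 3-cyanophenyl lying within the scatter, so among these three compounds only the 2-vinylphenyl group of compound 2 sets itself apart, while the 2-methoxyphenyl and 3-cyanophenyl groups cannot be told apart by this read-out. Nothing measured here offers an explanation for this result.

Because 3-cyanophenyl differs from 2-vinylphenyl in both the group and its place on the phenyl ring, the compounds shown do not separate these two changes, and 2-cyanophenyl or 3-vinylphenyl at this position would be needed to do so. Also open, going by these compounds, is how this number would respond to an amine, a carboxylic acid or a longer chain on the same phenyl ring.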